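Shortening the linker of iodoacetamide-bearing nucleotide derivatives

The source may hold more compounds than are shown below. What is called first, only, known or untested is meant among the compounds shown, and "the series" means these compounds.

The measured compounds are compound 1, `O=C(CI)NCCCCCC(=O)NCCCCCCNc1ncnc2c1ncn2[C@@H]1O[C@H](COP(=O)(O)OP(=O)(O)OP(=O)(O)O)[C@@H](O)[C@H]1O`, with 0%, and compound 2, `O=C(CI)NCCCCC(=O)NCCCCCCNc1ncnc2c1ncn2[C@@H]1O[C@H](COP(=O)(O)OP(=O)(O)OP(=O)(O)O)[C@@H](O)[C@H]1O`, with 0%.

In an assay on isolated protein for inhibition of hexokinase-3 (Rattus norvegicus), with a stated time of 6 h, tested at 10 mM (on this read-out lower numbers stand for less inhibition and higher numbers for more inhibition at the one concentration tested (going by the name of the read-out)), compound 1 gives 0%, and compound 2 gives 0%; the step of no change at the digits printed from compound 1 to compound 2 (within the scatter) is within the scatter, so compound 2 stands level with compound 1 on this read-out, and neither shows inhibition at the concentration tested.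

Compound 3, `O=C(CI)NCCCCCCCNc1ncnc2c1ncn2[C@@H]1O[C@H](COP(=O)(O)OP(=O)(O)OP(=O)(O)O)[C@@H](O)[C@H]1O`, carries a still shorter chain: a group of 6 heavy atoms (3 carbon, 1 nitrogen, 1 oxygen, 1 iodine; no ring) in place of a group of 12 heavy atoms (7 carbon, 2 nitrogen, 2 oxygen, 1 iodine; no ring), on a saturated chain carbon, six bonds along the chain from a nitrogen on an aromatic ring. Going by the values given here, the one measured step that bears on shortening this chain is no change at the digits printed from compound 1 to compound 2 (within the scatter), and it showed no change. On that ground, and with both measured compounds at the same value, the expected step of no change at the digits printed from compound 2 to compound 3 (within the scatter) is none beyond the scatter. Compound 3 is therefore estimated at 0%, in the range -8% to 10%.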

Compound 3, a percentage reported as inhibition, at one concentration (the size of the read-out at that concentration, not a potency): 20%
Beside the measured number, compound 3's estimate is 20 percentage points below it; the whole stated range lies below it.
By their numbers in this assay, from the lowest: compounds 1 and 2 (each within the scatter of the next); then compound 3.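

With this assay, this position proves able to move the read-out: putting (((iodomethyl)carbonyl)amino)methyl in place of the group of 12 heavy atoms, on a saturated chain carbon, six bonds along the chain from a nitrogen on an aromatic ring, gives a number 20 percentage points higher from compound 2 to compound 3 (beyond the scatter), a modest step. The earlier trim gave no change at the digits printed from compound 1 to compound 2 (within the scatter), so that change had left no visible mark, whereas this larger one, which also removes the inner amide, does. Nothing shown accounts for the rise.

Because the chain length and the inner amide change together, the compounds shown cannot say which of the two matters. Going by these compounds, it also remains open how an unbroken longer alkyl chain would read here, or an amine in place of the iodoacetamide end.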